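The source may report more compounds than this note shows. Statements on the series, on what has been measured and on what is new or still open speak of the compounds shown alone.

Compound 1 `Cc1cc(CNCc2ccccc2)c(C)n1-c1ccc(Cl)cc1`: 7.2 ug/mL
Compound 2 `Cc1cc(CNCc2ccccc2)c(C)n1-c1ccc(F)cc1`: 28 ug/mL

Among the compounds with values here, in an ADME assay on THP-1 cells (Homo sapiens) for cytotoxicity, read by trypan blue exclusion, with a stated time of 48 h (on this read-out lower numbers stand for stronger inhibition of growth and higher numbers for weaker inhibition of growth), compound 1 gives the lowest of the two numbers; its nearest neighbour is compound 2, and a 3.9-fold higher number from compound 1 to compound 2 (0.59 log units; beyond the scatter) is the only measured step in the set. Compound 3 `Cc1cc(CNCc2ccc(F)cc2)c(C)n1-c1ccc(Cl)cc1` differs from compound 1 by fluoro in place of hydrogen on an aromatic carbon. Within the data shown here, no measured step covers this change: the one known step concerns a different ring and a different exchange, so it does not bear on it directly. With nothing pointing either way, the expected step of a 1.1-fold higher number from compound 1 to compound 3 (0.05 log units; within the scatter) is none beyond the scatter. Compound 3 is therefore estimated at 8 ug/mL, within 3.5 ug/mL to 18 ug/mL.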

Compound 3, concentration for 50% growth inhibition: 8.4 ug/mL
Compound 3: middle estimate off by 1.1-fold (0.02 log units), on the low side; the range from low to high includes it.
By their numbers in this assay, from the lowest: compounds 1 and 3 (each within the scatter of the next); then compound 2.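

Fluoro in place of hydrogen on the benzyl ring, para to a large group, gives a 1.2-fold higher number from compound 1 to compound 3 (0.07 log units; within the scatter) in this assay and so no step beyond the scatter. Within the data shown here, the only earlier step, a 3.9-fold higher number from compound 1 to compound 2 (0.59 log units; beyond the scatter), was a halogen exchange on the other aromatic ring, so this is the first reading for the benzyl ring, where the added fluoro gives no separation between the two compounds. Nothing available gives a reason for this result.

Still open, going by these compounds, is whether a trifluoromethyl group, an amine or a carboxylic acid at the same place would move the number in this assay beyond the scatter. Also open, on these data alone, is whether chloro there would read as fluoro does.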